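Removing one methoxy group: effect on cytotoxicity

The source may hold more compounds than are shown below. What is called first, only, known or untested is meant among the compounds shown, and "the series" means these compounds.

Measured compounds:
compound 1 `COc1ccc(-c2cc(/C=C/C(=O)c3ccc(N)cc3)[nH]n2)cc1`: -61%
compound 2 `COc1cc(-c2cc(/C=C/C(=O)c3ccc(N)cc3)[nH]n2)cc(OC)c1OC`: -93%
compound 3 `COc1ccc(C(=O)/C=C/c2cc(-c3cc(OC)c(OC)c(OC)c3)n[nH]2)cc1`: -92%

In a functional assay on SF-539 cells (Homo sapiens) for cytotoxicity, read by sulforhodamine B assay, with a stated time of 48 h, tested at 10 uM (on this read-out higher numbers stand for a weaker effect at the one concentration tested and lower numbers for a stronger effect), compound 2 stands lowest of the three numbers; compound 3 lies nearest, with a number 1 percentage points higher from compound 2 to compound 3 (within the scatter), and compound 1 lies furthest, beyond the scatter. Compound 4 `COc1ccc(-c2cc(/C=C/C(=O)c3ccc(N)cc3)[nH]n2)cc1OC` is compound 2 with hydrogen in place of methoxy on an aromatic carbon. For the measured compounds named here, no measured step removes a methoxy group; the one step recorded, methoxy in place of amino on an aromatic carbon, is within the scatter and does not bear on this change. What bears on it are the values of compound 1 and compound 2, which differ beyond the scatter, compound 1 carrying one methoxy group where compound 2 carries three. Compound 4, carrying two, is expected to fall between them, with an expected step of a number 13 percentage points higher from compound 2 to compound 4 (beyond the scatter). Compound 4 is therefore estimated at -80%, between -97% and -60%.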

Compound 4, a percentage reported as activity, at one concentration (the size of the read-out at that concentration, not a potency): -73%
Compound 4: middle estimate off by 7 percentage points, on the low side; the measured number falls inside the stated range.
By their numbers in this assay, from the lowest: compounds 2 and 3 (each within the scatter of the next); then compound 4; then compound 1.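

In this assay, hydrogen in place of the methoxy group ortho to a methoxy group gives a number 20 percentage points higher from compound 2 to compound 4 (beyond the scatter), so this single group counts beyond the scatter. Methoxy in place of hydrogen at that same kind of site on compound 1 gives a number 12 percentage points lower from compound 1 to compound 4 (beyond the scatter), and the number falls stepwise from compound 1 through compound 4 to compound 2, with no compound in this trio going against it. Nothing available explains either step.

From the compounds shown here alone, whether a fluorine, a hydroxyl or an ethoxy group could serve at this position remains open. Also open, going by these compounds, is whether the step from removing methoxy holds in compounds with methoxy in place of amino.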